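The source may report more compounds than this note shows. Statements on the series, on what has been measured and on what is new or still open speak of the compounds shown alone.

Measured so far:
compound 1 `COc1ccc2nc(C)cc(OCC(=O)Nc3cc(C)cc(C)c3)c2c1` — 5.64
compound 2 `COc1ccc2nc(C)cc(OC(C)C(=O)Nc3cc(C)cc(C)c3)c2c1` — 5.76

In a physicochemical assay for lipophilicity, read by HPLC, in phosphate buffer, measured as chromatographic lipophilicity, at pH 7.4 (on this read-out lower numbers stand for lower lipophilicity and higher numbers for higher lipophilicity), compound 2 stands highest of the two numbers; the nearest is compound 1, which gives 5.64, a gap printed as within the scatter.

Compound 3 `CCC(Oc1cc(C)nc2ccc(OC)cc12)C(=O)Nc1cc(C)cc(C)c1` is not yet measured. It differs from compound 2 by methyl in place of hydrogen on a saturated chain carbon, two bonds along the chain from a carbonyl carbon and an oxygen on an aromatic ring.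

Within the data shown here, the one measured step that bears on this is the earlier homologation on the same chain carbon: a number 0.12 log units higher from compound 1 to compound 2 (within the scatter). That step added one carbon at this place and moved this assay only within the scatter. The change to compound 3 adds one further carbon at the same place, so a step of similar size, upward, is expected in this assay, possibly somewhat larger, but nothing that need clear the scatter with certainty.

For compound 3 the expected value in this assay is 6.1, range 5.7 to 6.5, meaning an expected step of a number 0.34 log units higher from compound 2 to compound 3 (beyond the scatter).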

Compound 3, distribution coefficient: 6.28
Beside the measured number, compound 3's estimate is 0.18 log units below it, within the range that was stated.
By their numbers in this assay, from the lowest: compounds 1 and 2 (each within the scatter of the next); then compound 3.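

At this saturated chain carbon, the methyl to ethyl change gives a number 0.52 log units higher from compound 2 to compound 3 (beyond the scatter) in this assay and so clears the scatter, unlike the earlier change, which gave a number 0.12 log units higher from compound 1 to compound 2 (within the scatter) for methyl in place of hydrogen. Ethyl in place of hydrogen at the same carbon gives a number 0.64 log units higher from compound 1 to compound 3 (beyond the scatter) in this assay and shows that this position can move the read-out once the substituent reaches ethyl. Nothing at hand accounts for the size of these steps.

Going by these compounds, whether a longer chain such as propyl, or a branched group such as isopropyl, would extend the rise at this carbon remains open. So does the effect of an amine or a carboxylic acid at the end of this chain on the read-out, since the compounds shown cover only hydrogen, methyl and ethyl here.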